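A few compounds are considered here, and "the series" means these few. Any claim that something is new, unique, unknown or untested is made for them only; others in the source may bear on it.

Measured in a functional assay, read by spectrophotometry, with a stated time of 30 min; a higher number here means a weaker inhibitor, a lower number a stronger inhibitor:

- compound 1 `O=C(/C=C/c1ccccc1)NCCC1CCN(Cc2ccccc2)CC1` gives > 200000 nM, which is a limit of the assay and not a number
- compound 2 `CC(C)(C)c1cc(CCC(=O)NCC2CCN(Cc3ccccc3)CC2)cc(C(C)(C)C)c1O` gives 63400 nM
- compound 3 `CC(C)(C)c1cc(/C=C/C(=O)NCCC2CCN(Cc3ccccc3)CC2)cc(C(C)(C)C)c1O` gives 81700 nM

Compound 3 sits at 81700 nM and compound 2 at 63400 nM. These two numbers lie within the usual scatter of each other, so they cannot be told apart and neither counts as the better inhibitor. Compound 1 reports only the limit > 200000 nM.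

The next compound to consider is compound 4 `COc1ccc(CN2CCC(CCNC(=O)/C=C/c3cc(C(C)(C)C)c(O)c(C(C)(C)C)c3)CC2)cc1`. It differs from compound 3 in one place: methoxy in place of hydrogen on an aromatic carbon. This is methoxy in place of hydrogen on an aromatic carbon, para to a large group, so that benzyl becomes 4-methoxybenzyl.

Within the data shown here, no pair of measured compounds shows what this change does in this assay, so the only anchor is compound 3 at 81700 nM. With nothing pointing either way, no shift beyond the scatter is expected, and the range must stay wide. The expected step, a 1.2-fold lower number from compound 3 to compound 4 (0.07 log units; within the scatter), is therefore small and has no firm direction. For compound 4 the estimated value is 70000 nM, with an expected range from 28000 nM to 175000 nM.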

Compound 4, half-maximal inhibitory concentration: 61200 nM
Compound 4: the middle estimate sits 1.1-fold (0.06 log units) above what was measured, and the stated range covers the measured number.
By their numbers in this assay, from the lowest: compounds 4, 2 and 3 (each within the scatter of the next). At a limit, above all of these: compound 1.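

In this assay, turning benzyl into 4-methoxybenzyl gives a 1.3-fold lower number from compound 3 to compound 4 (0.13 log units; within the scatter). Among these compounds, this is the first direct look at a change on this ring, since no earlier pair of compounds differed in one place, and it shows that a methoxy group on this aromatic carbon, para to a large group, leaves the two compounds impossible to tell apart. Compound 1 stands at a limit, which is not a number, whereas this step rests on two real numbers, so it is a true reading and is not cut off by the end of the assay's range: the limit of > 200000 nM in this assay, at which 1 of the 4 values shown sits.

A single substituent at a single position cannot show whether this carbon is insensitive to change in general, and an amine, a carboxylic acid or a longer chain such as butoxy at the same place could still move the number beyond the scatter. On these data alone, it also remains open whether methoxy would behave the same way on another carbon of this ring, or on the benzyl group of compound 2, whose linking chain differs.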